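The source may report more compounds than this note shows. Statements on the series, on what has been measured and on what is new or still open speak of the compounds shown alone.

Measured so far in a functional assay on MCF7 cells (Homo sapiens) for inhibition, read by MTT assay, with a stated time of 96 h; on this read-out lower numbers stand for stronger inhibition of growth and higher numbers for weaker inhibition of growth: compound 1 `O=C(NCCCCCCSSCCCCCCNC(=O)c1cc(-c2ccncc2)n[nH]1)c1cc(-c2ccncc2)n[nH]1` gives 7150 nM; compound 2 `C=CCOC(=O)SCCCCCCNC(=O)c1cc(-c2ccncc2)n[nH]1` gives 12600 nM; compound 3 `O=C(OCc1ccccc1)SCCCCCCNC(=O)c1cc(-c2ccncc2)n[nH]1` gives 8370 nM.

Compound 2 gives the highest of the three numbers, yet both its gap to compound 3 and its gap to compound 1 fall within the usual scatter, so the three cannot be told apart. Compound 4 `CC(=O)SCCCCCCNC(=O)c1cc(-c2ccncc2)n[nH]1` differs from compound 2 by methyl in place of allyloxy on a carbonyl carbon. Among the measured compounds shown here, the only measured step, a 1.5-fold lower number from compound 2 to compound 3 (0.18 log units; within the scatter), changes a different part of the same end group and lies within the scatter, so it offers no sign that small changes at this end shift this assay. Compound 4 is therefore expected to stay close to compound 2, with a 1.1-fold lower number from compound 2 to compound 4 (0.06 log units; within the scatter) as the anticipated step. The estimate for compound 4 is 11000 nM, within a range of 4500 nM to 27000 nM.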

Compound 4, concentration for 50% growth inhibition: 24900 nM
Beside the measured number, compound 4's estimate is 2.3-fold (0.35 log units) below it, and the stated range covers the measured number.
By their numbers in this assay, from the lowest: compounds 1, 3, 2 and 4 (each within the scatter of the next, the first and the last beyond it).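

Among the compounds shown here, putting methyl in place of benzyloxy on the carbonyl carbon gives the first step here that lies beyond the scatter, though a modest one (a 3.0-fold higher number from compound 3 to compound 4 (0.47 log units; beyond the scatter)), so this end group can register in this assay. Methyl in place of allyloxy stays within the scatter (a 2.0-fold higher number from compound 2 to compound 4 (0.30 log units; within the scatter)), so this signal rests on a single pair. Nothing available accounts for the step.

From the compounds shown here alone, whether an amine on this carbonyl carbon, or a longer chain in place of methyl, would shift the number remains open.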